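A few compounds are considered here, and "the series" means these few. Any claim that something is new, unique, unknown or untested is made for them only; others in the source may bear on it.

Compound 1 `CC(C)(C)OC(=O)N1CCN(C(=S)SCc2cn(-c3ccccc3F)nn2)CC1`, compound 2 `O=C(OCc1ccccc1)N1CCN(C(=S)SCc2cn(Cc3ccc(Cl)cc3)nn2)CC1` and compound 3 `CC(C)(C)OC(=O)N1CCN(C(=S)SCc2cn(Cc3cc(=O)oc4cc(O)ccc34)nn2)CC1` have each been tested in a functional assay on ECa-109 cells (Homo sapiens) for inhibition, read by MTT assay, with a stated time of 72 h; on this read-out lower numbers stand for stronger inhibition and higher numbers for weaker inhibition. For compound 1 the result is a limit of the assay rather than a number, > 128000 nM. Compound 3 likewise gives only a limit, > 128000 nM. Compound 2, the starting point of the step followed here, also gives only a limit, > 128000 nM. All three results thus rest at the same point, (the limit of > 128000 nM in this assay, at which 3 of the 3 values shown sit), and none of the three can be placed above or below another; compound 2 stands level with its two companions at the limit.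

Compound 4 `O=C(OCc1ccccc1)N1CCN(C(=S)SCc2cn(Cc3ccc(F)cc3)nn2)CC1` has not yet been measured in this assay. It differs from compound 2 in a single place: fluoro in place of chloro on an aromatic carbon, so that the 4-chlorobenzyl group of compound 2 becomes the 4-fluorobenzyl group of compound 4. Going by the values given here, no step between two measured compounds exists to show how such an exchange behaves; the only guidance is the common limit, (the limit of > 128000 nM in this assay, at which 3 of the 3 values shown sit), shared by every measured compound. The step from compound 2 to compound 4 is therefore expected to be a step that the limit leaves unreadable from compound 2 to compound 4, nothing beyond the usual scatter. Compound 4 is estimated at 200000 nM, within a range of 100000 nM to 500000 nM, most likely reported again only as a limit.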

Compound 4, half-maximal inhibitory concentration: 32000 nM
The estimate for compound 4 lay 6.3-fold (0.80 log units) above the measured number; the whole stated range lies above it.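

In this assay, fluoro in place of chloro on the aromatic carbon para to a large group gives an at least 4.0-fold lower number from compound 2 to compound 4 (0.60 log units; beyond the scatter). This place on the ring is therefore not silent: exchanging one halogen atom for another, with no ring, hydrogen-bond donor, hydrogen-bond acceptor or net charge entering or leaving, is enough to bring compound 4 to a measurable number, and it is the only compound shown that has one. The step can be read only as a lower bound on the real difference, because compound 2 gives a limit and not a number: the limit of > 128000 nM in this assay, at which 3 of the 4 values shown sit.

The compounds shown leave open whether a bromo, methoxy, nitrile or amine at this same place, or the plain benzyl group with nothing there, would give a lower number than the 4-fluorobenzyl group or return to the limit. They also leave open whether the same exchange of chloro for fluoro would give a step of this kind if the benzyl ester end of the carbamate were replaced by a tert-butyl group.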